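Urea-to-amide swap on the shared core

The source may hold more compounds than are shown below. What is called first, only, known or untested is meant among the compounds shown, and "the series" means these compounds.

Compound 2 `COc1cc(Cl)cc(-c2nn(-c3cccc(NC(=O)Nc4ccc(Cl)c(Cl)c4)c3)cc2-c2ccncc2)c1` is the methyl ether of compound 1 `O=C(Nc1cccc(-n2cc(-c3ccncc3)c(-c3cc(O)cc(Cl)c3)n2)c1)Nc1ccc(Cl)c(Cl)c1`. In a functional assay on MOLT-4 cells (Homo sapiens) for inhibition, read by sulforhodamine B assay, with a stated time of 48 h, tested at 0.1 uM (a lower number here means a stronger effect, a higher number a weaker effect of the compound at the concentration tested), compound 1 gives 94%, and in this assay compound 2 gives 88%. Within the data shown here, the only measured step, a number 6 percentage points lower from compound 1 to compound 2 (within the scatter), concerns methyl in place of hydrogen on an oxygen on an aromatic ring and does not separate the two compounds. Compound 2 thus stands as the lowest of two numbers, with compound 1 nearest and within the scatter of it.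

Compound 3 `COc1cc(Cl)cc(-c2nn(-c3cccc(NC(=O)c4cccc(C(F)(F)F)c4)c3)cc2-c2ccncc2)c1` differs from compound 2 at a different place: 3-(trifluoromethyl)phenyl in place of (3,4-dichlorophenyl)amino on a carbonyl carbon. Among the measured compounds shown here, no measured step touches the carbonyl carbon or the group attached to it, so the one step known, which ran elsewhere on the core, gives no direct guide to the size or direction of this change. With both measured compounds sitting close together in this assay, the working expectation for compound 3 is a step of a number 2 percentage points higher from compound 2 to compound 3 (within the scatter), that is, nothing beyond the scatter. The estimated value for compound 3 in this assay is 90%, within a range from 70% to 105%.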

Compound 3, a percentage reported as activity, at one concentration (the size of the read-out at that concentration, not a potency): 95%
For compound 3 the middle estimate is 5 percentage points below the measured one, and the stated range covers the measured number.
By their numbers in this assay, from the lowest: compounds 2, 1 and 3 (each within the scatter of the next).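

Working notes on the carbonyl position: in this assay the first step at this place is a number 7 percentage points higher from compound 2 to compound 3 (within the scatter) and does not separate the two compounds, although (3,4-dichlorophenyl)amino, which carries a hydrogen-bond donor, gives way to 3-(trifluoromethyl)phenyl, which carries none. The earlier step covered only the oxygen on an aromatic ring, so this result adds a second place on the shared core, and an exchange of urea for amide, where no effect can be resolved at the single concentration tested. No available evidence accounts for this outcome or shows how the two groups compare in any property.

Still open, going by these compounds, is whether an amine such as morpholine, a carboxylic acid or a longer alkyl chain in place of 3-(trifluoromethyl)phenyl on the carbonyl carbon would give a step beyond the scatter in this assay at all. Also open is how the free hydroxyl of compound 1 would read when paired with the amide of compound 3, and the single-concentration read-out gives no potency for any of these compounds.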